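Swapping the Aryl Group on the Triazole Nitrogen

The source may hold more compounds than are shown below. What is called first, only, known or untested is meant among the compounds shown, and "the series" means these compounds.

Measured so far in an ADME assay on HeLa cells (Homo sapiens) for cytotoxicity, read by MTT assay; a lower number here means a stronger inhibitor, a higher number a weaker inhibitor:
Compound 1 `COc1ccc(C[C@H]2COC(=O)[C@@H]2Cc2ccc(OCC(=O)Nc3ccc(C)cc3)c(OC)c2)cc1OC` gives 228000 nM.
Compound 2 `COc1ccc(C[C@H]2COC(=O)[C@@H]2Cc2ccc(OCc3cn(Cc4ccccc4F)nn3)c(OC)c2)cc1OC` is reported only as a limit of the assay, >= 600000 nM.
Compound 3 `COc1ccc(C[C@H]2COC(=O)[C@@H]2Cc2ccc(OCc3cn(-c4cccc(Cl)c4)nn3)c(OC)c2)cc1OC` gives 493000 nM.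

Compound 3 holds the highest of the two numbers recorded; the other number lies one modest step below it, a 2.2-fold higher number from compound 1 to compound 3 (0.33 log units; beyond the scatter), a step that goes with the 1-(3-chlorophenyl)-1H-1,2,3-triazol-4-yl in place of the (4-methylphenyl)carbamoyl group.

Compound 4 `COc1ccc(-n2cc(COc3ccc(C[C@H]4C(=O)OC[C@@H]4Cc4ccc(OC)c(OC)c4)cc3OC)nn2)cc1` differs from compound 3 in a single place: 4-methoxyphenyl in place of 3-chlorophenyl on an aromatic nitrogen. Among the measured compounds shown here, only one measured step touches the same place, and it is small: an at least 1.2-fold lower number from compound 2 to compound 3 (0.08 log units; that floor lies within the scatter), a floor that lies within the scatter. The exchange of one six-membered aromatic ring for another on the same nitrogen therefore gives no reason to expect a move beyond the scatter in either direction.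

Compound 4 is accordingly expected to give about 500000 nM, within a range from 250000 nM to 1000000 nM. The expected step is a 1.0-fold higher number from compound 3 to compound 4 (0.01 log units; within the scatter), which is to say essentially none. Because the limit of >= 600000 nM in this assay, at which 1 of the 3 values shown sits, sits close above the number for compound 3, there is a fair chance that compound 4 is likewise reported only as a limit rather than as a number.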

Compound 4, half-maximal inhibitory concentration: >= 600000 nM
Compound 4: no number, only a limit; the forecaster's own chance of this, stated with the estimate: 40%; middle value at least 1.2-fold (0.07 log units) away from the limit.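

Compound 4 is reported as the limit >= 600000 nM in this assay and not as a number. Putting 4-methoxyphenyl in place of 3-chlorophenyl gives an at least 1.2-fold higher number from compound 3 to compound 4 (0.08 log units; that floor lies within the scatter) and leaves the true size of the change unknown, since only its floor can be read. With 2-fluorobenzyl, 3-chlorophenyl and 4-methoxyphenyl now seen on this aromatic nitrogen, no step at this position is shown to go beyond the scatter, the step between the two limit compounds, compound 2 and compound 4, cannot be read, and the upper end of the assay now restricts what this position can reveal: the limit of >= 600000 nM in this assay, at which 2 of the 4 values shown sit.

Among the compounds shown here, what stays open is whether any group on this nitrogen can bring the number clearly down from that of compound 3, which is the only compound of the three with this kind of substituent to give a measured number. An amine or a carboxylic acid on the aromatic ring, or a longer chain between the ring and the nitrogen, would test this in a part of the range where differences can still be measured.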